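The source may hold more compounds than are shown below. What is called first, only, known or untested is meant among the compounds shown, and "the series" means these compounds.

Compound 1 `O=c1oc2ccccc2c(N2CCN(c3ccccc3)CC2)c1CO`: > 50000 nM
Compound 2 `O=c1oc2ccccc2c(N2CCN(c3ccc(F)cc3)CC2)c1CO`: > 50000 nM
Compound 3 `O=c1oc2ccccc2c(N2CCN(c3cccc(Cl)c3)CC2)c1CO`: > 50000 nM

All three entries come from a functional assay on WM1361 cells (Homo sapiens) for inhibition, read by MTT assay, with a stated time of 24 h (a higher number here means a weaker inhibitor, a lower number a stronger inhibitor), and each is a limit of the assay, not a number. The series therefore stands at the limit of > 50000 nM in this assay, at which 3 of the 3 values shown sit. Compound 3 has no exact value either, and its > 50000 nM is a limit.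

The next compound is compound 4 `CCN1CCN(c2c(CO)c(=O)oc3ccccc23)CC1`. It keeps the shared core of compound 3 and carries ethyl in place of 3-chlorophenyl on an amine nitrogen in a ring.

The measured steps offer little guidance. They are a step that the two limits leave unreadable from compound 1 to compound 2, a step that the two limits leave unreadable from compound 1 to compound 3 and a step that the two limits leave unreadable from compound 2 to compound 3. The last of these, also a change on an amine nitrogen in a ring, comes nearest, yet it has no readable size. None of the three puts ethyl in that place.

With no size to carry over, no step beyond the scatter is expected in this assay, in either direction. The expectation starts from compound 3, whose > 50000 nM is a limit. The expected outcome is a number no higher from compound 3 to compound 4 (the limit leaves the size open). For compound 4 the estimated value is 50000 nM, with an expected range from 15000 nM to 120000 nM.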

Compound 4, half-maximal inhibitory concentration: > 100000 nM
Compound 4: only a limit was reported; the forecaster's own chance of this, stated with the estimate: 70%; middle value at least 2.0-fold (0.30 log units) away from the limit.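

In this assay compound 4 gives > 100000 nM, which is a limit of the assay and not a number. The steps to compound 4 from compound 1, compound 2 and compound 3 cannot be read, as all four entries are limits. The compounds shown leave open how strong any of them is in this assay, and whether ethyl, phenyl, 4-fluorophenyl or 3-chlorophenyl on the amine nitrogen makes any difference there.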